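The compounds below may be only part of what the source reports. "The series", "measured", "known", "first", "only" and "open" are said of these compounds alone.

Measured so far:
compound 1 `Cc1ccc(-c2ccnc(C(=O)Nc3ccc(Oc4ccnc5[nH]ccc45)cc3)c2)cc1`: > 10000 nM.
compound 2 `O=C(Nc1ccc(Oc2ccnc3[nH]ccc23)cc1)c1cc(-c2ccccc2)ccn1`: 3270 nM.
compound 3 `Cc1ccc(-c2ccnc(C(=O)Nc3ccc(Oc4ccnc5[nH]ccc45)c(F)c3)c2)c(C)c1`: 4010 nM.

In a functional assay on PC-3 cells (Homo sapiens) for cytotoxicity, read by MTT assay, with a stated time of 72 h (a lower number here means a stronger inhibitor, a higher number a weaker inhibitor), compound 1 gives > 10000 nM, which is a limit of the assay rather than a number (the limit of > 10000 nM in this assay, at which 1 of the 3 values shown sits). Compound 2 gives 3270 nM, and compound 3 gives 4010 nM; these two lie within the usual scatter of each other, so compound 3 stands alongside compound 2 among the numbers shown. Going by the values given here, the one measured step that changes a single place, an at least 3.0-fold lower number from compound 1 to compound 2 (0.48 log units; beyond the scatter), took away a methyl and strengthened inhibition. Compound 4 `O=C(Nc1ccc(Oc2ccnc3[nH]ccc23)c(F)c1)c1cc(-c2ccc(C(F)(F)F)cc2)ccn1` differs from compound 3 by 4-(trifluoromethyl)phenyl in place of 2,4-dimethylphenyl on an aromatic carbon. Among the compounds with values here, this also removes the two methyls while bringing in a trifluoromethyl, for which no measured step exists; the step from compound 1 to compound 2 suggests a modest gain. Compound 4 is expected to give 1500 nM, between 500 nM and 5000 nM, an expected 2.7-fold lower number from compound 3 to compound 4 (0.43 log units; beyond the scatter).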

Compound 4, half-maximal inhibitory concentration: 4350 nM
Compound 4: the middle estimate sits 2.9-fold (0.46 log units) below what was measured, within the range that was stated.
By their numbers in this assay, from the lowest: compounds 2, 3 and 4 (each within the scatter of the next). At a limit, above all of these: compound 1.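

Replacing 2,4-dimethylphenyl with 4-(trifluoromethyl)phenyl, on the aromatic carbon opposite the ring nitrogen, gives a 1.1-fold higher number from compound 3 to compound 4 (0.04 log units; within the scatter) and so makes no difference that can be read. The earlier change at this position, an at least 3.0-fold lower number from compound 1 to compound 2 (0.48 log units; beyond the scatter), lay beyond the scatter, so not every change to this phenyl ring counts alike. No measurement shown bears on why this exchange leaves the reading unmoved. The compounds shown leave open whether an amine or a carboxylic acid on this phenyl ring would lower the number. They also leave open whether a change here can bring a clear gain when the ring carries fluorine-free groups of other kinds.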